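This account rests on a few compounds, and the source may have more. Where it says the series, first, only, none or still open, it means among the compounds named here.

Compound 2 `COc1cc2nc(NCCCN3CCCC3=O)nc(NC3CCCCCC3)c2cc1OC` gives 8% in an in vitro assay on B300-19 cells for displacement of a labelled ligand from C-C chemokine receptor type 4 (Homo sapiens), tested at 1 uM; a lower number here means less inhibition, a higher number more inhibition at the concentration tested (going by the name of the read-out). For the measured compounds named here, its only measured neighbour, compound 1 `COc1cc2nc(NCCN3CCCCC3)nc(NC3CCCCCC3)c2cc1OC`, gives 18% in this assay, and the difference, a number 10 percentage points lower from compound 1 to compound 2 (within the scatter), is too small to separate the two, so both are simply weak at the concentration tested. Compound 3 `COc1cc2nc(N3CCC(C(N)=O)CC3)nc(NC3CCCCCC3)c2cc1OC` is the unmeasured compound. Compared with compound 2, (4-carbamoylpiperidin-1-yl in place of (3-(2-oxopyrrolidin-1-yl)propyl)amino on an aromatic carbon). Going by the values given here, the single measured step, a number 10 percentage points lower from compound 1 to compound 2 (within the scatter), exchanged one group on the chain and stayed within the scatter; the present change is of a different kind, as the whole chain-linked group leaves and a ring is joined to the aromatic carbon directly, so that earlier step bears on it only loosely. Among the compounds with values here, with both measured numbers low and the one step flat, a step of a number 4 percentage points higher from compound 2 to compound 3 (within the scatter) is expected, meaning no change beyond the scatter. Compound 3 is therefore expected to give 12% in this assay, within a range from 0% to 35%.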

Compound 3, a percentage reported as inhibition, at one concentration (the size of the read-out at that concentration, not a potency): < 0%
Compound 3 ended at the assay's limit; the forecaster's own chance of this, stated with the estimate: 0%; middle value at least 12 percentage points away from the limit.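

With 4-carbamoylpiperidin-1-yl on this aromatic carbon, compound 3 stands at a limit of this assay, not at a number: the limit of < 0% in this assay, at which 1 of the 3 values shown sits. For the compounds shown here, putting this group in place of (2-(piperidin-1-yl)ethyl)amino gives a number at least 18 percentage points lower from compound 1 to compound 3 (beyond the scatter), the first step to clear the scatter, so the group at this position can shift the read-out even at these low levels. Putting it in place of (3-(2-oxopyrrolidin-1-yl)propyl)amino gives a number at least 8 percentage points lower from compound 2 to compound 3 (that floor lies within the scatter), so that exchange cannot be told apart from no change.

From the compounds shown here alone, none of the three compounds shows more than weak inhibition at the concentration tested, so what would raise it remains open. A longer chain ending in piperidine, or a carboxylic acid in place of the carbamoyl group, could still be tried at this position.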